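The source may hold more compounds than are shown below. What is called first, only, known or untested is meant among the compounds shown, and "the series" means these compounds.

Measured compounds in an ADME assay on Vero cells (Chlorocebus sabaeus) for cytotoxicity, read by MTT assay, with a stated time of 72 h; on this read-out higher numbers stand for lower toxicity in this test and lower numbers for higher toxicity in this test:
compound 1 `c1ccc([C@@H]2C[C@@H]3Cc4ccc5ccccc5c4N2O3)cc1`: 72900 nM
compound 2 `Brc1ccc([C@@H]2C[C@@H]3Cc4ccc5ccccc5c4N2O3)cc1`: > 250000 nM, a limit of the assay
compound 3 `Clc1cccc([C@@H]2C[C@@H]3Cc4ccc5ccccc5c4N2O3)c1`: > 300000 nM, a limit of the assay

Compound 3 stands only at a limit in this assay, and compound 2 also sits at a limit, so the step that the two limits leave unreadable from compound 2 to compound 3 cannot be read. Compound 4 `Cc1cccc([C@@H]2C[C@@H]3Cc4ccc5ccccc5c4N2O3)c1` differs from compound 3 by methyl in place of chloro on an aromatic carbon, on the ring that carries the 3-chlorophenyl. The two readable steps both add a halogen to compound 1: an at least 3.4-fold higher number from compound 1 to compound 2 (0.53 log units; beyond the scatter) and an at least 4.1-fold higher number from compound 1 to compound 3 (0.61 log units; beyond the scatter). Among the measured compounds shown here, no measured step introduces a methyl, so the exchange of chloro for methyl has no direct precedent in this set. The expected step of an at least 2.0-fold lower number from compound 3 to compound 4 (0.30 log units; that floor lies within the scatter) is therefore uncertain in size and direction. Compound 4 is estimated at 150000 nM in this assay, between 50000 nM and 400000 nM.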

Compound 4, half-maximal cytotoxic concentration: > 300000 nM
Compound 4: a limit, no number (the forecaster's own chance of this, stated with the estimate: 40%); middle value at least 2.0-fold (0.30 log units) from the limit.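

In this assay, the change to 3-methylphenyl gives an at least 4.1-fold higher number from compound 1 to compound 4 (0.61 log units; beyond the scatter), so among the compounds shown, a step of this kind does not depend on a halogen. Compound 4 stands at a limit of the assay, not at a number: the limit of > 300000 nM in this assay, at which 2 of the 4 values shown sit. The steps from compound 2 and compound 3 to compound 4 cannot be read, so chloro and methyl cannot be ordered at this position.

Going by these compounds, it remains open how far these three substituted compounds lie beyond compound 1. An amine or a carboxylic acid at this position also remains untested among the compounds shown.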